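From a Benzyl Group Back to a Phenyl Group

This account rests on a few compounds, and the source may have more. Where it says the series, first, only, none or still open, it means among the compounds named here.

Among the compounds with values here, compound 2 `CCCn1c(=O)[nH]c2nc(-c3ccc(S(=O)(=O)N4CCN(Cc5cccc(C)c5)CC4)cc3)[nH]c2c1=O` gives 17% in an assay on CHO cells for displacement of a labelled ligand from adenosine receptor A3 (Homo sapiens), read by scintillation counting, with a stated time of 45 min, tested at 1 uM, in the presence of a further agent that is not named here (a lower number here means less inhibition, a higher number more inhibition at the concentration tested (going by the name of the read-out)), the lower of the two numbers measured so far. Compound 1 `CCCn1c(=O)[nH]c2nc(-c3ccc(S(=O)(=O)N4CCN(c5ccc(Br)cc5)CC4)cc3)[nH]c2c1=O` gives 29% in this assay, and the step of a number 12 percentage points lower from compound 1 to compound 2 (beyond the scatter) is the only one measured. Compound 3 `CCCn1c(=O)[nH]c2nc(-c3ccc(S(=O)(=O)N4CCN(c5ccccc5C)CC4)cc3)[nH]c2c1=O` differs from compound 2 by 2-methylphenyl in place of 3-methylbenzyl on an amine nitrogen in a ring. Within the data shown here, that change reverses the kind of move seen in the one measured step, placing an aromatic ring of carbon only on the amine nitrogen in the ring again, as in compound 1. Compound 3 is therefore expected to rise by about a number 8 percentage points higher from compound 2 to compound 3 (within the scatter) toward the number of compound 1, to an estimated 25%, within 10% to 40%.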

Compound 3, a percentage reported as inhibition, at one concentration (the size of the read-out at that concentration, not a potency): 25%
Beside the measured number, compound 3's estimate shows no gap at the digits printed; low and high end bracket the measured number.
By their numbers in this assay, from the lowest: compounds 2, 3 and 1 (each within the scatter of the next, the first and the last beyond it).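

In this assay the 2-methylphenyl group on the amine nitrogen in a ring cannot be told apart from either earlier group, with a number 8 percentage points higher from compound 2 to compound 3 (within the scatter) and a number 4 percentage points lower from compound 1 to compound 3 (within the scatter). Within the data shown here, compound 1 and compound 2 remain the only pair separated beyond the scatter, and exchanging 4-bromophenyl for 2-methylphenyl on that nitrogen gives no readable difference. Open, going by these compounds, is whether a plain phenyl, or a longer chain ending in an amine or a carboxylic acid, would move the number at this nitrogen. Nothing measured here explains these numbers.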